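Compound 2 to compound 4: one group exchanged

The source may hold more compounds than are shown below. What is called first, only, known or untested is meant among the compounds shown, and "the series" means these compounds.

In a physicochemical assay for pharmacokinetics (on this read-out higher numbers stand for a longer-lived compound and lower numbers for a shorter-lived compound), compound 2 `COc1ccc(CNC(=O)N2C(=O)c3ccccc3S2(=O)=O)cc1` gives 0.187 h. Going by the values given here, this sits at the low end of the numbers so far, within the scatter of compound 3 `O=C(NCc1ccc(C(F)(F)F)cc1)N1C(=O)c2ccccc2S1(=O)=O` at 0.212 h, while compound 1 `CC(NC(=O)N1C(=O)c2ccccc2S1(=O)=O)c1ccccc1` stands clearly higher at 0.663 h.

Compound 4 `Cc1ccccc1CNC(=O)N1C(=O)c2ccccc2S1(=O)=O` has not yet been measured. It differs from compound 2 by a single exchange: 2-methylphenyl in place of 4-methoxyphenyl on a saturated chain carbon bound to an amide-type nitrogen.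

Among the compounds with values here, only one measured step bears on this exchange, and it is only a partial guide. It also removes a methoxy group, giving a 1.1-fold higher number from compound 2 to compound 3 (0.05 log units; within the scatter), so the number stayed within the scatter. Within the data shown here, no measured compound carries the 2-methylphenyl group, so the range must stay wide, and the value of compound 1 at 0.663 h shows that higher numbers occur in this small set.

The expected change is a 1.2-fold higher number from compound 2 to compound 4 (0.07 log units; within the scatter), which would be no real step beyond the scatter. For compound 4, the estimated half-life in this assay is 0.22 h, with an expected range from 0.11 h to 0.5 h.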

Compound 4, half-life: 0.792 h
Compound 4: middle estimate off by 3.6-fold (0.56 log units), on the low side; the measured number lies above the stated range.
By their numbers in this assay, from the lowest: compounds 2 and 3 (each within the scatter of the next); then compounds 1 and 4 (each within the scatter of the next).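

In this assay the ring on this saturated chain carbon proves able to move the number: 2-methylphenyl in place of 4-methoxyphenyl gives a 4.2-fold higher number from compound 2 to compound 4 (0.63 log units; beyond the scatter), whereas trifluoromethyl in place of methoxy gave only a 1.1-fold higher number from compound 2 to compound 3 (0.05 log units; within the scatter). Losing the methoxy group therefore does not always leave the number unchanged, since compound 3 and compound 4 both lack it and only the step to compound 4 lies beyond the scatter. No measurement here explains the size of this step.

The exchange changes both the group on the ring and where it stands, so the compounds shown cannot say which of the two matters. A 4-methylphenyl or a 2-methoxyphenyl group on the same chain carbon would pull these two changes apart.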